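The source may hold more compounds than are shown below. What is called first, only, known or untested is meant among the compounds shown, and "the series" means these compounds.

Measured so far:
Compound 1, `Cc1ccc(NC(=S)NC(=O)c2ccc(OCc3cccc(F)c3)cc2)cc1-c1nc2ccccc2[nH]1`: > 100000 nM
Compound 2, `Cc1ccc(NC(=S)NC(=O)c2ccc(OCc3ccccc3Cl)cc2)cc1-c1nc2ccccc2[nH]1`: 57100 nM
Compound 3, `Cc1ccc(NC(=O)NC(=O)c2ccc(OCc3ccc(C(F)(F)F)cc3)cc2)cc1-c1nc2ccccc2[nH]1`: 15300 nM

In a functional assay on SW-620 cells (Homo sapiens) for inhibition, read by MTT assay, with a stated time of 48 h (on this read-out lower numbers stand for stronger inhibition and higher numbers for weaker inhibition), compound 1 reaches only a limit of the assay, > 100000 nM, and no number. Compound 2 gives 57100 nM in this assay. Compound 3 gives 15300 nM, the lower of the two numbers shown; its gap to compound 2 lies beyond the usual scatter.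

Compound 4, `Cc1ccc(NC(=O)NC(=O)c2ccc(OCc3ccccc3Cl)cc2)cc1-c1nc2ccccc2[nH]1`, is not yet measured. It differs from compound 3 in one place: 2-chlorophenyl in place of 4-(trifluoromethyl)phenyl on a saturated chain carbon bound to an oxygen on an aromatic ring. Among the compounds with values here, only one measured step bears on this change, an at least 1.7-fold lower number from compound 1 to compound 2 (0.24 log units; that floor lies within the scatter), where the same 2-chlorophenyl entered, though in place of 3-fluorophenyl and on a core that differs from that of compound 3. That step starts from a limit, so its size is only a floor that lies within the scatter, and it shows no clear direction.

On this evidence the step is expected to stay within the scatter, and compound 4 is estimated to give about 15000 nM in this assay, between 5000 nM and 50000 nM, which means an expected step of a 1.0-fold lower number from compound 3 to compound 4 (0.01 log units; within the scatter).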

Compound 4, half-maximal inhibitory concentration: 35700 nM
The estimate for compound 4 lay 2.4-fold (0.38 log units) below the measured number, within the range that was stated.
By their numbers in this assay, from the lowest: compound 3; then compounds 4 and 2 (each within the scatter of the next). At a limit, above all of these: compound 1.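

In this assay, placing 2-chlorophenyl in place of 4-(trifluoromethyl)phenyl on the saturated chain carbon bound to an oxygen on an aromatic ring gives a 2.3-fold higher number from compound 3 to compound 4 (0.37 log units; beyond the scatter), a modest step, but the first at this place with a clear direction. The earlier step at this place gave only a floor, because the value of compound 1 is a limit and not a number: the limit of > 100000 nM in this assay, at which 1 of the 4 values shown sits. The new step shows that the number in this assay does respond to the ring carried at this place, at least between this one pair of compounds, with 4-(trifluoromethyl)phenyl giving the lower number.

This single step changes both the ring's substituent and where that substituent sits, so the compounds shown cannot tell which of the two accounts for the difference. From the compounds shown here alone, how this place would respond to a ring carrying an amine or a carboxylic acid, or to a longer chain between the oxygen and the ring, remains open.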